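A Second Chloro Group Tested on a Thiourea Analogue

The source may hold more compounds than are shown below. What is called first, only, known or untested is meant among the compounds shown, and "the series" means these compounds.

Compound 1 `Cc1c(S(=O)(=O)N/C(=N\O)Nc2ccc(Cl)cc2)sc2ccc(Cl)cc12`: 29 ug/mL in a functional assay on KB cells (Homo sapiens) for cytotoxicity; a higher number here means a weaker inhibitor, a lower number a stronger inhibitor
Compound 2 `Cc1c(S(=O)(=O)N/C(=N\O)Nc2ccc(Cl)c(Cl)c2)sc2ccc(Cl)cc12`: a limit of the assay, > 300 ug/mL
Compound 3 `Cc1ccc(S(=O)(=O)/N=C(\S)Nc2ccc(Cl)cc2)cc1`: 80 ug/mL in this assay

In this assay the change chloro in place of hydrogen on an aromatic carbon gave an at least 10-fold higher number from compound 1 to compound 2 (1.01 log units; beyond the scatter), and the value of compound 2 sits at the limit of > 300 ug/mL in this assay, at which 1 of the 3 values shown sits. The difference between the core of compound 1 and the core of compound 3 is not broken down here.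

Compound 4 `Cc1ccc(S(=O)(=O)/N=C(\S)Nc2ccc(Cl)c(Cl)c2)cc1` carries the same change as that step, (chloro in place of hydrogen on an aromatic carbon), made on the core of compound 3. In this assay, for the measured compounds named here, a step like the one from compound 1 to compound 2 is expected from compound 3 to compound 4, a 3.8-fold higher number from compound 3 to compound 4 (0.57 log units; beyond the scatter), because compound 3 already gives 80 ug/mL. Compound 4 is therefore estimated at 300 ug/mL in this assay, likely reaching the limit of the assay.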

Compound 4, half-maximal inhibitory concentration: 41 ug/mL
Compound 4: middle estimate off by 7.3-fold (0.86 log units), on the high side; measured number below the stated range.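

In this assay, adding the second chloro group to the core of compound 3 gave a 2.0-fold lower number from compound 3 to compound 4 (0.29 log units; within the scatter), so this change had no clear effect on this core. The change therefore did not carry over from one core to the other with the same result: the same change on two cores in this assay, an at least 10-fold higher number (1.01 log units; beyond the scatter) from compound 1 to compound 2 and a 2.0-fold lower number (0.29 log units; within the scatter) from compound 3 to compound 4, at least 20-fold (1.30 log units) apart, beyond the scatter of two such steps Compound 2 gives > 300 ug/mL, which is a limit of the assay and not a number, and this single pair of steps does not show which difference between the two cores goes with the different outcome.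

From the compounds shown here alone, it remains open how an amine or a methoxy group in place of the added chloro would behave on each core. Also open, going by these compounds, is whether the same split would appear on other cores.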